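The source may report more compounds than this note shows. Statements on the series, on what has been measured and on what is new or still open speak of the compounds shown alone.

Going by the values given here, compound 2 `C=CCc1cc(C(C)=O)c(O)cc1OCCCCC#N` stands highest of the two numbers so far in an assay on isolated protein for binding affinity to leukotriene B4 receptor 1 (Homo sapiens), tested at 1 uM (a lower number here means less inhibition, a higher number more inhibition at the concentration tested (going by the name of the read-out)), where compound 2 gives 57%. Compound 1 `CC(=O)c1cc(C(C)=O)c(OCCCCC#N)cc1O` gives 0% in this assay. Among the compounds with values here, the one measured step, a number 57 percentage points higher from compound 1 to compound 2 (beyond the scatter), concerns an aromatic carbon, not the chain. Compound 3 `C=CCc1cc(C(C)=O)c(O)cc1OCCCCCCC` differs from compound 2 by propyl in place of cyano on a saturated chain carbon, four bonds along the chain from an oxygen on an aromatic ring. Within the data shown here, no measured step touches this chain, so the size of the change cannot be read from the series; for compound 3 the expected step is a number 7 percentage points lower from compound 2 to compound 3 (within the scatter), with a wide range. Compound 3 is estimated at 50%, between 15% and 85%.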

Compound 3, a percentage reported as inhibition, at one concentration (the size of the read-out at that concentration, not a potency): 8%
Compound 3: the middle estimate sits 42 percentage points above what was measured; the whole stated range lies above it.
By their numbers in this assay, from the lowest: compounds 1 and 3 (each within the scatter of the next); then compound 2.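

In this assay, the end of this chain matters as much as the aromatic carbon did: propyl in place of cyano, four bonds along the chain from an oxygen on an aromatic ring, gives a large loss (a number 49 percentage points lower from compound 2 to compound 3 (beyond the scatter)). The allyl group is therefore not enough on its own to keep the inhibition seen with compound 2, since compound 3 carries it too. No evidence on hand accounts for this loss.

On these data alone, it remains open whether a carboxylic acid or a primary amide at this chain end, or a longer chain still ending in a nitrile, would keep the inhibition. This single pair also cannot separate losing the cyano group from adding propyl.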